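A pyrazolyl in place of a hydroxypropyl on the amide nitrogen

A few compounds are considered here, and "the series" means these few. Any claim that something is new, unique, unknown or untested is made for them only; others in the source may bear on it.

Compound 1, `Cc1ccc(OCC(=O)N(CCCO)Cc2cccs2)cc1`, gives 3000 nM
Compound 2, `CCN(Cc1cccs1)C(=O)CCc1ccc(C)cc1`, gives 93 nM
Compound 3, `CCN(Cc1nccs1)C(=O)COc1ccc(C)cc1`, gives 3060 nM

Of the compounds shown here, three have so far been measured in an assay on HEK293 cells for agonist activity at transient receptor potential cation channel subfamily M member 8 (Homo sapiens), read by fluorescence and calcium flux, with a stated time of 15 min; on this read-out higher numbers stand for an effect only at larger amounts of compound and lower numbers for an effect already at smaller amounts. Compound 1 stands second highest of the three numbers. Its nearest neighbour is compound 3, whose value lies within the scatter of that of compound 1, so no order between these two can be claimed. The furthest is compound 2, whose value lies well below that of compound 1 and beyond the scatter. Within the data shown here, no pair of measured compounds differs in a single place, so no measured step can guide the next change.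

Compound 4, `Cc1ccc(OCC(=O)N(Cc2cccs2)c2cn[nH]c2)cc1`, differs from compound 1 in one place: 1H-pyrazol-4-yl in place of 3-hydroxypropyl on an amide-type nitrogen. The measured compounds contain nothing resembling this change, and the comparison of compound 1 with compound 2 and compound 3 involves several changes at once. The step from compound 1 to compound 4 is therefore expected to be small, no change at the digits printed from compound 1 to compound 4 (within the scatter), with no clear direction beyond the scatter. Compound 4 is estimated to give 3000 nM in this assay, within a range from 800 nM to 12000 nM.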

Compound 4, half-maximal effective concentration: 1.4 nM
Compound 4: middle estimate off by 2100-fold (3.33 log units), on the high side; measured number below the stated range.
By their numbers in this assay, from the lowest: compound 4; then compound 2; then compounds 1 and 3 (each within the scatter of the next).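

In this assay, among these compounds, the group on this amide-type nitrogen proves decisive: 1H-pyrazol-4-yl in place of 3-hydroxypropyl gives a 2100-fold lower number from compound 1 to compound 4 (3.33 log units; beyond the scatter), a large step and the first measured between compounds that differ in one place. The earlier compounds shown here could not show this, since they differ from one another in several places at once and so could not isolate the effect of this nitrogen's substituent. The two groups match in hydrogen-bond donors, hydrogen-bond acceptors and net charge, so those counts do not separate them, and nothing at hand explains why the exchange has so large an effect.

The compounds shown leave open whether the step belongs to the five-membered aromatic ring as such or to its hetero atoms and ring hydrogen, a question that a phenyl or a 1-methyl-1H-pyrazol-4-yl on the same nitrogen would address. They also leave open whether 1H-pyrazol-4-yl would have a similar effect in place of the ethyl on the amide-type nitrogen of compound 2 or compound 3.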